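This account rests on a few compounds, and the source may have more. Where it says the series, first, only, none or still open, it means among the compounds named here.

Measured compounds:

- compound 1, `c1ccc(-c2nnn[nH]2)c(-c2ccc(CCc3nc(CC4CCCC4)c[nH]3)cc2)c1`: 15 nM
- compound 2, `O=C1NC(=O)C(c2ccccc2-c2ccc(CCC3N=CC(CC4CCCC4)=N3)cc2)S1`: 287 nM
- compound 3, `CCC(C)(C)Cc1c[nH]c(CCc2ccc(-c3ccccc3OCc3ncn[nH]3)cc2)n1`: 22 nM

These three compounds were tested in an assay on isolated protein for binding affinity to Bombesin receptor subtype-3 (Homo sapiens); on this read-out lower numbers stand for stronger inhibition and higher numbers for weaker inhibition. Among them compound 3 holds the second highest number; its nearest neighbour is compound 1, whose value sits within the usual scatter of the measurement, so the two cannot be told apart. Compound 2 stands well apart, with a number beyond the scatter above that of compound 3.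

Compound 4, `CCC(C)(C)Cc1c[nH]c(CCc2ccc(-c3ccccc3OCc3cnn[nH]3)cc2)n1`, has not yet been measured. It shares every atom with compound 3; the two differ only in how the atoms are joined: 1H-1,2,3-triazol-5-yl in place of 1H-1,2,4-triazol-5-yl on a saturated chain carbon bound to an oxygen on an aromatic ring. The change swaps one five-membered ring with three nitrogen atoms for another of the same count and kind, with the same numbers of hydrogen-bond donors and acceptors.

Within the data shown here, no pair of measured compounds shows this particular swap, so its effect cannot be read from the data. With the same atoms and the same donor and acceptor counts kept, the expected step in this assay from compound 3 to compound 4 is small, a 1.4-fold higher number from compound 3 to compound 4 (0.13 log units; within the scatter), and likely within the scatter in either direction. Compound 4 is therefore expected to give about 30 nM, within a range from 10 nM to 90 nM.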

Compound 4, half-maximal inhibitory concentration: 83 nM
The estimate for compound 4 lay 2.8-fold (0.44 log units) below the measured number, within the range that was stated.
By their numbers in this assay, from the lowest: compounds 1 and 3 (each within the scatter of the next); then compound 4; then compound 2.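

In this assay, the swap of 1H-1,2,4-triazol-5-yl for 1H-1,2,3-triazol-5-yl on a saturated chain carbon bound to an oxygen on an aromatic ring gives a 3.8-fold higher number from compound 3 to compound 4 (0.58 log units; beyond the scatter) and so registers at this position. The two groups have the same atoms and the same counts of hydrogen-bond donors and acceptors, so those counts alone do not fix the number here, and how the atoms of the ring are joined also matters. Nothing available accounts for this step.

Among these compounds, whether the same swap gives a step of similar size on a different side chain, such as the one in compound 1, stays open. Also open, going by these compounds, is how a carboxylic acid or a pyrazole would read in this assay when placed on the same saturated chain carbon.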